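The source may report more compounds than this note shows. Statements on the series, on what has been measured and on what is new or still open speak of the compounds shown alone.

Series notes. Compound 1 `Nc1ncnc2c1ncn2C1O[C@H](CO)[C@H](O[C@@H]2OC(CO)[C@H](OP(=O)(O)O)C(OP(=O)(O)O)[C@@H]2O)[C@@H]1OP(=O)(O)O` gives 14 nM in a functional assay (Hepatocyte) with Rattus norvegicus as the target (a lower number here means that less compound is needed, a higher number that more compound is needed for the effect), and stands at one end of the two numbers measured, with compound 2 `O=P(O)(O)OC1[C@@H](OP(=O)(O)O)C(CO)O[C@@H](O[C@@H]2[C@H](OP(=O)(O)O)C(n3cnc4c(NC5CCCCC5)ncnc43)O[C@@H]2CO)[C@H]1O`, which gives 25 nM in this assay, within the scatter of it. Going by the values given here, that pair is the only step measured: a 1.8-fold higher number from compound 1 to compound 2 (0.25 log units; within the scatter), for cyclohexyl in place of hydrogen on a nitrogen on an aromatic ring. Compound 3 `O=P(O)(O)OC1[C@@H](OP(=O)(O)O)C(CO)O[C@@H](O[C@@H]2[C@H](OP(=O)(O)O)C(n3cnc4c(NC5CCCC5)ncnc43)O[C@@H]2CO)[C@H]1O` is not yet measured; against compound 1 the change is cyclopentyl in place of hydrogen on a nitrogen on an aromatic ring. The cyclohexyl step bears on it and stayed within the scatter, so no step beyond the scatter is expected in this assay. Compound 3 is therefore expected to give 22 nM, between 10 nM and 50 nM, a step of a 1.6-fold higher number from compound 1 to compound 3 (0.20 log units; within the scatter).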

Compound 3, half-maximal effective concentration: 13 nM
Compound 3: the middle estimate sits 1.7-fold (0.23 log units) above what was measured; measured number inside the range.
By their numbers in this assay, from the lowest: compounds 3, 1 and 2 (each within the scatter of the next).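

In this assay, the cyclopentyl change on this nitrogen gives a 1.1-fold lower number from compound 1 to compound 3 (0.03 log units; within the scatter), so a second carbon ring, after cyclohexyl, stays within the scatter of the unsubstituted amino compound. Changing the ring size gives a 1.9-fold lower number from compound 2 to compound 3 (0.28 log units; within the scatter), so the two rings cannot be separated here, and compounds 1, 2 and 3 carry no order among them. This position therefore accepts both rings without a step beyond the scatter.

On these data alone, whether an open butyl chain, a phenyl ring or a carboxylic acid on the same nitrogen would also stay within the scatter remains open. Nothing available explains why these numbers stay so close.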